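The compounds below may be only part of what the source reports. "The series", "measured", "known", "first", "only" and "open" are said of these compounds alone.

Two amides of the shared core have been measured. Compound 1 `CCCCNC(=O)C1=CC(C)(C)Oc2ccc([N+](=O)[O-])cc21` gives 83.2% in a functional assay on the whole organism (muscle tissue) with Rattus norvegicus as the target; a lower number here means a smaller maximal response, a higher number a larger maximal response. Within the data shown here, compound 2 `CC(C)NC(=O)C1=CC(C)(C)Oc2ccc([N+](=O)[O-])cc21` gives 77.6% in this assay, the lower of the two numbers, but the only measured step, a number 5.6 percentage points lower from compound 1 to compound 2 (within the scatter), lies within the scatter, so compound 2 and compound 1 cannot be ordered.

The next step leads to compound 3 `CC1(C)C=C(C(=O)NCCO)c2cc([N+](=O)[O-])ccc2O1`. The change is 2-hydroxyethyl in place of isopropyl on an amide-type nitrogen. Among the measured compounds shown here, the one measured step, a number 5.6 percentage points lower from compound 1 to compound 2 (within the scatter), exchanges one alkyl group for another on the same amide-type nitrogen and does little; no measured pair shows what a hydroxyl-bearing group on this nitrogen does, so that part of the change is uncovered by the numbers.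

Given that the only known change at this position, a number 5.6 percentage points lower from compound 1 to compound 2 (within the scatter), stays within the scatter, compound 3 is expected to give a maximal response near that of compound 2, a step of a number 2.6 percentage points lower from compound 2 to compound 3 (within the scatter), with a wider range because the hydroxyl group is untested. The estimate for compound 3 is 75%, between 55% and 92%.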

Compound 3, intrinsic activity: the largest response reached, in percent of the reference agonist's: 71.8%
Compound 3: middle estimate off by 3.2 percentage points, on the high side; measured number inside the range.
By their numbers in this assay, from the lowest: compounds 3, 2 and 1 (each within the scatter of the next, the first and the last beyond it).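

On the amide-type nitrogen, 2-hydroxyethyl in place of isopropyl adds a hydrogen-bond donor and a hydrogen-bond acceptor, yet this assay shows a number 5.8 percentage points lower from compound 2 to compound 3 (within the scatter) and so does not separate these two amides. Among these compounds, the comparison with the butyl amide, hydroxy in place of ethyl on a saturated chain carbon, two bonds along the chain from an amide-type nitrogen, gives a number 11.4 percentage points lower from compound 1 to compound 3 (beyond the scatter) and is the first step at this nitrogen to clear the scatter, although compound 2 stays within the scatter of both neighbours and the order therefore holds only between the two ends of the series. No measurement on hand accounts for either step.

The step from the butyl amide joins the hydroxyl group to a shorter chain, and a plain ethyl amide on the same nitrogen would be needed to separate the two parts of that change. From the compounds shown here alone, how 2-aminoethyl, carboxymethyl or a longer chain such as 4-hydroxybutyl on this nitrogen would read in this assay remains open, as does whether any group here can move the maximal response by more than this modest step.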